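A second (pyrrolidin-1-yl)methyl group on compound 1

A few compounds are considered here, and "the series" means these few. Any claim that something is new, unique, unknown or untested is made for them only; others in the source may bear on it.

Measured in a functional assay on K562 cells (Homo sapiens) for antiproliferative activity, read by MTT assay, with a stated time of 48 h; a higher number here means a weaker inhibitor, a lower number a stronger inhibitor:
- compound 1 `Oc1ccc2cc1Oc1ccc(cc1)CCc1ccc(CN3CCCC3)c(O)c1-c1ccc(cc1O)CC2`: 4820 nM
- compound 2 `CN1CCN(Cc2ccc3c(c2O)-c2ccc(cc2O)CCc2ccc(O)c(c2)Oc2ccc(cc2)CC3)CC1`: 3310 nM
- compound 3 `CCCCN(CCCC)Cc1ccc2c(c1O)-c1ccc(cc1O)CCc1ccc(O)c(c1)Oc1ccc(cc1)CC2`: > 20000 nM

Among the measured compounds shown here, compound 1 and compound 2 hold the only two numbers, and they lie within the scatter of each other, with a 1.5-fold lower number from compound 1 to compound 2 (0.16 log units; within the scatter). Compound 3 gives > 20000 nM, which is a limit of the assay and not a number.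

Compound 4 `Oc1cc2ccc1-c1c(ccc(CN3CCCC3)c1O)CCc1ccc(cc1)Oc1cc(cc(CN3CCCC3)c1O)CC2` is compound 1 with one further change: (pyrrolidin-1-yl)methyl in place of hydrogen on an aromatic carbon. A (pyrrolidin-1-yl)methyl group stands in place of hydrogen on an aromatic carbon, ortho to a hydroxy group. For the measured compounds named here, no measured step adds such a group, so the evidence is only indirect. The three measured steps all exchange the amine on the saturated chain carbon. The exchange for dibutylamino gives an at least 4.1-fold higher number from compound 1 to compound 3 (0.61 log units; beyond the scatter) and an at least 6.0-fold higher number from compound 2 to compound 3 (0.78 log units; beyond the scatter), whereas the step to 4-methylpiperazin-1-yl is the small one given above. The new group in compound 4 carries the same pyrrolidin-1-yl as compound 1, not the dibutylamino of compound 3, so no shift beyond the scatter is expected, though with wide uncertainty. In this assay the estimated step is a 1.2-fold lower number from compound 1 to compound 4 (0.08 log units; within the scatter). For compound 4 the expected value is 4000 nM, with an estimated range from 1300 nM to 13000 nM.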

Compound 4, half-maximal inhibitory concentration: 800 nM
The estimate for compound 4 lay 5.0-fold (0.70 log units) above the measured number; the measured number lies below the stated range.
By their numbers in this assay, from the lowest: compound 4; then compounds 2 and 1 (each within the scatter of the next). At a limit, above all of these: compound 3.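

Placing (pyrrolidin-1-yl)methyl in place of hydrogen on an aromatic carbon, ortho to a hydroxy group, gives a 6.0-fold lower number from compound 1 to compound 4 (0.78 log units; beyond the scatter) in this assay and is the only step shown that lowers the number beyond the scatter. Among the compounds shown here, the earlier steps all exchanged the amine on the saturated chain carbon, and they either stayed within the scatter or raised the number, so this position on the core of compound 1 is the first change seen to give a lower number beyond the scatter. Nothing among the data shown explains why the added group has this effect.

On these data alone, whether the lower number belongs to pyrrolidin-1-yl itself stays open, as does whether another amine at this position, such as 4-methylpiperazin-1-yl, dibutylamino or morpholin-4-yl, would give a similar step. As far as these compounds go, it is equally open whether a plain methyl or hydroxymethyl group would do the same, and whether the new group needs the first (pyrrolidin-1-yl)methyl group of compound 1 to stand with it.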